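Thioether for ether on the aryl side chain

The compounds below may be only part of what the source reports. "The series", "measured", "known", "first", "only" and "open" are said of these compounds alone.

Values to date in an ADME assay on microsomes from liver (Rattus norvegicus) for metabolic stability, read by LC-MS, tested at 0.5 uM; on this read-out lower numbers stand for a shorter-lived compound and higher numbers for a longer-lived compound:

Compound 1 `Cc1nc(C)c([C@H](OC(C)(C)C)C(=O)O)c(N2CCC(C)(C)CC2)c1-c1ccc(OCCc2ccc(F)cc2F)cc1`: in this assay compound 1 gives > 2 h, a limit of the assay and not a number.
Compound 2 `Cc1nc(C)c([C@H](OC(C)(C)C)C(=O)O)c(N2CCC(C)(C)CC2)c1-c1ccc(OCCc2cc(F)c(F)cc2F)cc1`: in this assay compound 2 gives > 2 h, again a limit.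
Compound 3 `Cc1nc(C)c([C@H](OC(C)(C)C)C(=O)O)c(N2CCC(C)(C)CC2)c1-c1ccc(OCCCc2ccc(F)cc2)cc1`: in this assay compound 3 gives > 2 h, likewise a limit.

Compound 3 therefore stands at the limit, in the same place as the other two, with no number of its own. The steps among the measured compounds carry no readable size: a step that the two limits leave unreadable from compound 1 to compound 2, a step that the two limits leave unreadable from compound 1 to compound 3, and a step that the two limits leave unreadable from compound 2 to compound 3. What the series shows is only (the limit of > 2 h in this assay, at which 3 of the 3 values shown sit).

Compound 4 `Cc1nc(C)c([C@H](OC(C)(C)C)C(=O)O)c(N2CCC(C)(C)CC2)c1-c1ccc(SCCc2ccc(F)cc2)cc1` differs from compound 3 by (2-(4-fluorophenyl)ethyl)sulfanyl in place of 3-(4-fluorophenyl)propoxy on an aromatic carbon. For the measured compounds named here, no measured step alters the atom that links the chain to the aryl ring, and the measured steps have no readable size, so no step size can be carried over to this change. Because the limit of > 2 h in this assay, at which 3 of the 3 values shown sit, puts every value at the limit, compound 4 is expected to sit there too, and the step from compound 3 to compound 4 is estimated as a step that the limit leaves unreadable from compound 3 to compound 4. The estimate for compound 4 is 2.2 h, with a range from 0.8 h to 6 h and a fair chance that this assay again reports only a limit.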

Compound 4, half-life: > 2 h
Compound 4 gave a limit, no number; the forecaster's own chance of this, stated with the estimate: 55%; the middle value lies beyond the limit too.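

Compound 4 gives > 2 h, a limit and not a number. For the compounds shown here, no step to compound 4 from compound 1, compound 2 or compound 3 can be read. The compounds shown leave open whether (2-(4-fluorophenyl)ethyl)sulfanyl in place of 3-(4-fluorophenyl)propoxy changes the half-life at all in this assay.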